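A Difluorophenyl Swap Near the Limit of Cytotoxicity

The source may hold more compounds than are shown below. What is called first, only, known or untested is meant among the compounds shown, and "the series" means these compounds.

Within the data shown here, in an ADME assay on MT4 cells (Homo sapiens) for cytotoxicity, read by MTT assay (on this read-out lower numbers stand for higher toxicity in this test and higher numbers for lower toxicity in this test), compound 3 (`Cc1cc(C)cc(S(=O)(=O)c2c(C(=O)NC(C)C(=O)NCc3ccncn3)[nH]c3ccc(Cl)cc23)c1`) gives 28100 nM as the only true number among the three compounds tested so far. Compound 1 (`COc1cccc(F)c1CNC(=O)c1[nH]c2ccc(Cl)cc2c1S(=O)(=O)c1cc(C)cc(C)c1`) reads > 49900 nM and this is a limit of the assay, not a number. Compound 2 (`Cc1cc(C)cc(S(=O)(=O)c2c(C(=O)NC(c3ccc(Cl)cc3)C3CC3)[nH]c3ccc(Cl)cc23)c1`) reads > 47300 nM and this too is a limit.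

Compound 4 (`Cc1cc(C)cc(S(=O)(=O)c2c(C(=O)NC(C)c3cc(F)cc(F)c3)[nH]c3ccc(Cl)cc23)c1`) is still unmeasured. It differs from compound 3 by one change: 3,5-difluorophenyl in place of ((pyrimidin-4-yl)methyl)carbamoyl on a saturated chain carbon bound to an amide-type nitrogen and a saturated chain carbon.

Among the measured compounds shown here, two measured steps bear on this change, as both swap the group on an amide-type nitrogen. One is an at least 1.7-fold lower number from compound 1 to compound 3 (0.24 log units; that floor lies within the scatter) and the other is an at least 1.6-fold lower number from compound 2 to compound 3 (0.22 log units; that floor lies within the scatter) and neither gives a firm size. A six-membered aromatic ring of carbon only enters with compound 4, as in compound 1 and compound 2, so the expected direction reverses an at least 1.6-fold lower number from compound 2 to compound 3 (0.22 log units; that floor lies within the scatter) and points to higher numbers. The expected step is a 1.4-fold higher number from compound 3 to compound 4 (0.15 log units; within the scatter) and no clear change beyond the scatter is foreseen. In this assay the estimate for compound 4 is 40000 nM and it is expected to fall between 18000 nM and 60000 nM.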

Compound 4, half-maximal cytotoxic concentration: > 49700 nM
Compound 4 gave a limit, no number (the forecaster's own chance of this, stated with the estimate: 50%); middle value at least 1.2-fold (0.09 log units) away from the limit.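

Putting 3,5-difluorophenyl in place of ((pyrimidin-4-yl)methyl)carbamoyl on a saturated chain carbon bound to an amide-type nitrogen and a saturated chain carbon gives an at least 1.7-fold higher number from compound 3 to compound 4 (0.24 log units; that floor lies within the scatter) in this assay, and this is the first step shown that alters only this part of the group on the amide-type nitrogen. With this result, compounds 1, 2 and 4, which all carry a six-membered aromatic ring of carbon only in that group, read as limits, while compound 3, with its six-membered aromatic ring holding 2 hetero atoms, is the only one that gives a true number, although the floor of the step leaves no firm difference beyond the scatter. The reading of compound 4 is a limit of the assay and not a number: the limit of > 49700 nM in this assay, at which 1 of the 4 values shown sits.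

The steps from compound 1 and from compound 2 to compound 4 join two limits and cannot be read. Still open, going by these compounds, is whether the pyrimidine ring or the carbamoyl that carries it goes with the true number of compound 3, and whether a pyridine ring or a primary amine on this saturated chain carbon would give a number or a limit.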